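The source may hold more compounds than are shown below. What is called first, only, known or untested is meant among the compounds shown, and "the series" means these compounds.

Compound 3 `Cc1cccc(/C(N)=N/NC(=S)N2CCCC2)n1` sits second highest among the three compounds measured in a functional assay on HeLa cells (Homo sapiens) for cytotoxicity, read by MTT assay, with a stated time of 72 h, tested at 3 uM (a lower number here means less inhibition of growth, a higher number more inhibition of growth at the concentration tested), where compound 3 gives 56.8%. Its nearest neighbour is compound 2 `N/C(=N\NC(=S)N1CCSCC1)c1ccccn1`, which in this assay gives 39.7%, a gap beyond the usual scatter. The furthest is compound 1 `N/C(=N\NC(=S)N1CCCC1)c1ccc(F)cn1`, which in this assay gives 77.7%, again a gap beyond the scatter. All three share the same core, differing only in the group on the aromatic ring and in the saturated ring attached to the thiocarbonyl.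

The step of interest leads from compound 3 to compound 4 `N/C(=N\NC(=S)N1CCCC1)c1ccccn1`. The change is hydrogen in place of methyl on an aromatic carbon: a hydrogen in place of a methyl on an aromatic carbon of the six-membered aromatic ring with one nitrogen, next to the ring nitrogen and meta to a large group. Within the data shown here, no pair of measured compounds differs in exactly this way, so the size of the step cannot be read from a measured example. Compound 2, which also lacks a substituent on that ring but carries a different saturated ring, gives the lowest number, while compound 1 with a fluorine on that ring gives the highest, so the three values do not point clearly in one direction.

The step from compound 3 to compound 4 is therefore expected to be a number 1.2 percentage points higher from compound 3 to compound 4 (within the scatter), within the scatter. Compound 4 is estimated at 58%, with a range from 35% to 80%.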

Compound 4, percent growth inhibition at one concentration: 38.5%
Compound 4: middle estimate off by 19.5 percentage points, on the high side; the range from low to high includes it.
By their numbers in this assay, from the lowest: compounds 4 and 2 (each within the scatter of the next); then compound 3; then compound 1.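

In this assay, among these compounds, the pair compound 3 and compound 4, which share the pyrrolidin-1-yl group, gives the first direct reading of this change: hydrogen in place of methyl on an aromatic carbon next to the ring nitrogen gives a number 18.3 percentage points lower from compound 3 to compound 4 (beyond the scatter) and so shows that this position is not indifferent to the methyl group. Hydrogen in place of fluoro on an aromatic carbon gives a number 39.2 percentage points lower from compound 1 to compound 4 (beyond the scatter) and so places compound 4, with no substituent on that ring, below both substituted compounds that carry the pyrrolidin-1-yl group. Pyrrolidin-1-yl in place of thiomorpholin-4-yl on a thiocarbonyl carbon gives a number 1.2 percentage points lower from compound 2 to compound 4 (within the scatter) and so does not separate the two saturated rings on this unsubstituted ring.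

On these data alone, what an ethyl chain, a methoxy group or an amine on that aromatic carbon would give remains open, as does whether the methyl step holds with thiomorpholin-4-yl in place of pyrrolidin-1-yl. Nothing among the data shown accounts for the size of these steps.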